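From Pyridin-2-yl to Pyrimidin-2-yl: One More Ring Nitrogen

The compounds below may be only part of what the source reports. "The series", "measured", "known", "first", "only" and "open" are said of these compounds alone.

Three compounds have been measured in an ADME assay on HEK293 cells for displacement of a labelled ligand from 5-hydroxytryptamine receptor 7 (Homo sapiens), read by radioligand binding, with a stated time of 1 h; a higher number here means a weaker inhibitor, a lower number a stronger inhibitor:

compound 1, `O=C1c2ccccc2S(=O)(=O)N1CCCCCCN1CCN(c2cccc(Cl)c2Cl)CC1`, gives 119 nM
compound 2, `O=C1c2ccccc2S(=O)(=O)N1CCCCCCN1CCN(c2ccccc2)CC1`, gives 192 nM
compound 3, `O=C1c2ccccc2S(=O)(=O)N1CCCCCCN1CCN(c2ccccn2)CC1`, gives 552 nM

Compound 3 stands highest of the three numbers. Its nearest neighbour is compound 2, and that gap is beyond the scatter; the furthest is compound 1, with a larger gap, also beyond the scatter. The steps that lead to compound 3 are a 4.6-fold higher number from compound 1 to compound 3 (0.67 log units; beyond the scatter) and a 2.9-fold higher number from compound 2 to compound 3 (0.46 log units; beyond the scatter), both modest in size; the step of a 1.6-fold higher number from compound 1 to compound 2 (0.21 log units; within the scatter) lies within the scatter.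

Compound 4, `O=C1c2ccccc2S(=O)(=O)N1CCCCCCN1CCN(c2ncccn2)CC1`, is the next step: pyrimidin-2-yl in place of pyridin-2-yl on an amine nitrogen in a ring. Among the measured compounds shown here, the step that bears on it most directly is the one from compound 2 to compound 3, where one ring nitrogen entered the aryl group and the number rose modestly. A second ring nitrogen is therefore expected to push the number in the same direction, by a step of similar or somewhat smaller size, in this assay. That expectation corresponds to a 2.0-fold higher number from compound 3 to compound 4 (0.30 log units; within the scatter).

For compound 4 the estimated value in this assay is 1100 nM, with an expected range from 500 nM to 2600 nM.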

Compound 4, inhibition constant: 35 nM
The estimate for compound 4 lay 31-fold (1.50 log units) above the measured number; the measured number lies below the stated range.
By their numbers in this assay, from the lowest: compound 4; then compounds 1 and 2 (each within the scatter of the next); then compound 3.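

In this assay, the place on the amine nitrogen in a ring does not answer to ring nitrogens in one direction: the change from pyridin-2-yl to pyrimidin-2-yl gives a 16-fold lower number from compound 3 to compound 4 (1.20 log units; beyond the scatter) and so reverses the rise seen when pyridin-2-yl replaced phenyl, which means the count of ring nitrogens alone does not order these compounds. Among the compounds shown here, with a 5.5-fold lower number from compound 2 to compound 4 (0.74 log units; beyond the scatter) and a 3.4-fold lower number from compound 1 to compound 4 (0.53 log units; beyond the scatter) as well, pyrimidin-2-yl stands as the strongest of the four aryl groups, ahead of both phenyl and 2,3-dichlorophenyl, so the best group here is not one that the earlier compounds pointed towards. Nothing available here explains why the second ring nitrogen turns the trend around.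

The compounds shown leave open whether this gain belongs to pyrimidin-2-yl specifically or would also appear with a pyrazin-2-yl or pyrimidin-4-yl group, and whether a methyl group or a chlorine on the pyrimidin-2-yl ring would keep it. They also leave open whether it survives a shorter or a longer chain than the one in the shared core.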